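A few compounds are considered here, and "the series" means these few. Any claim that something is new, unique, unknown or untested is made for them only; others in the source may bear on it.

Measured compounds:
Compound 1 `N#Cc1ccc2ccc(C(=O)c3ccc(F)c(O)c3)nc2c1` gives 56%
Compound 2 `Oc1cc(Nc2cccc(-c3cccc(O)c3F)n2)ccc1F` gives 82%
Compound 3 `C=C(c1ccc(F)c(O)c1)c1cccc(-c2cccc(O)c2F)n1` gives 100%

In an assay for inhibition of 17-beta-hydroxysteroid dehydrogenase type 2 (Homo sapiens), read by HPLC, with a stated time of 10 min, tested at 1 uM (a lower number here means less inhibition, a higher number more inhibition at the concentration tested (going by the name of the read-out)), compound 1 stands lowest of the three. Compound 2 lies nearer to it, yet its number is higher by a margin beyond the usual scatter, and compound 3 lies furthest, higher again by a margin beyond the scatter. Compound 2 and compound 3 share a different linkage and a second phenol, so their gap to compound 1 cannot be pinned to any one change.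

Compound 4 `O=C(c1ccc(F)c(O)c1)c1ccc2ccccc2n1` has not been measured in this assay. It differs from compound 1 in one place: hydrogen in place of cyano on an aromatic carbon The cyano sits on an aromatic carbon of the fused two-ring system of compound 1, meta and para to the fused ring, and in compound 4 a hydrogen takes its place. Going by the values given here, no pair of measured compounds shows this kind of change, so the size of its step in this assay has to be guessed rather than read off. Among the compounds with values here, a small loss, close to or only slightly beyond the scatter, is expected, since the cyano is the only group removed and the rest of compound 1 is kept.

Compound 4 is therefore estimated at 45%, within a range from 20% to 70%, which is expected to mean a step of a number 11 percentage points lower from compound 1 to compound 4 (beyond the scatter).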

Compound 4, a percentage reported as inhibition, at one concentration (the size of the read-out at that concentration, not a potency): 76%
For compound 4 the middle estimate is 31 percentage points below the measured one; the whole stated range lies below it.
By their numbers in this assay, from the lowest: compound 1; then compounds 4 and 2 (each within the scatter of the next); then compound 3.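

In this assay, going by these compounds alone, hydrogen in place of cyano on an aromatic carbon of the fused system of two rings gives a step of a number 20 percentage points higher from compound 1 to compound 4 (beyond the scatter), the first change in this set that can be read in one place. The earlier compounds shown here differ from one another in several places and could not show what this position contributes. The step shows that the nitrile is not needed at this position for inhibition at the concentration tested, and that the number rises without it, although nothing available explains this gain.

With only one replacement shown at this position, it remains open whether the gain is specific to hydrogen or would also appear with a small group such as a methoxy, an amine or a carboxylic acid on the same carbon. Also open is how much of the number for compound 4 rests on its carbonyl, as no pair shown changes that linkage alone.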